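Swapping 2-methoxyphenyl for 3-chlorophenyl in compound 1

The source may report more compounds than this note shows. Statements on the series, on what has been measured and on what is new or still open speak of the compounds shown alone.

Going by the values given here, in a functional assay on HT-29 cells (Homo sapiens) for antiproliferative activity, read by sulforhodamine B assay, with a stated time of 48 h (on this read-out lower numbers stand for stronger inhibition and higher numbers for weaker inhibition), compound 1 `COc1ccccc1OS(=O)(=O)c1ccc(N2CCN(C)C2=O)cc1` gives 26000 nM, the highest number of the three measured so far. Compound 2 `Cc1ccc(OS(=O)(=O)c2ccc(N3CCN(C)C3=O)cc2)c(C)c1` gives 3000 nM, and compound 3 `CN1CCN(c2ccc(S(=O)(=O)Oc3c(Cl)cc(Cl)cc3Cl)cc2)C1=O`, which also bears chlorine in this group, gives 2500 nM. Compound 4 `CN1CCN(c2ccc(S(=O)(=O)Oc3cccc(Cl)c3)cc2)C1=O` is not yet measured. It carries 3-chlorophenyl in place of 2-methoxyphenyl on an oxygen. Among the compounds with values here, the only measured step that removes the same group is an 8.7-fold lower number from compound 1 to compound 2 (0.94 log units; beyond the scatter), with 2,4-dimethylphenyl entering. Within the data shown here, no measured compound carries 3-chlorophenyl itself, so a step in the same direction, of similar or somewhat smaller size, is expected. The expected step is a 5.2-fold lower number from compound 1 to compound 4 (0.72 log units; beyond the scatter). Compound 4 is estimated at 5000 nM, with an expected range from 1800 nM to 14000 nM.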

Compound 4, half-maximal inhibitory concentration: 2100 nM
Estimate against measurement, compound 4: 2.4-fold (0.38 log units) above; the measured number falls inside the stated range.
By their numbers in this assay, from the lowest: compounds 4, 3 and 2 (each within the scatter of the next); then compound 1.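

With 3-chlorophenyl on the oxygen bonded to the sulfonyl sulfur, the replacement of 2-methoxyphenyl gives a 12-fold lower number from compound 1 to compound 4 (1.09 log units; beyond the scatter), showing that a second, different group also lowers the number at this place. Exchanging 2,4-dimethylphenyl for 3-chlorophenyl gives a 1.4-fold lower number from compound 2 to compound 4 (0.15 log units; within the scatter), so these two groups cannot be told apart here. Nothing available bears on the cause of these differences.

Going by these compounds, whether an amine or a carboxylic acid on this phenyl ring would keep the number this low remains open. Also open, on these data alone, is whether the methoxy group itself is what sets compound 1 apart.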